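The compounds below may be only part of what the source reports. "The series", "measured", "known", "first", "only" and "open" are said of these compounds alone.

Working notes on the series.

Compound 1 `O=C1O/C(=C\Cn2cnc3c(F)nc(F)c(Cl)c32)C(OCc2ccccc2)=C1OCc1ccccc1` carries the shared core linked to a halogenated fused heterocycle; in a functional assay on CCRF-CEM cells (Homo sapiens) for antiproliferative activity, read by MTT assay, with a stated time of 72 h (on this read-out lower numbers stand for stronger inhibition and higher numbers for weaker inhibition), compound 1 gives "not determined" (no result reported), so no number stands against it and it cannot be placed within the series. Going by the values given here, compound 2 `O=C1O/C(=C\Cn2cnc3ccn(C/C=C4\OC(=O)C(OCc5ccccc5)=C4OCc4ccccc4)c3c2=O)C(OCc2ccccc2)=C1OCc1ccccc1` is the only member with a reported figure: in this assay compound 2 gives 19000 nM, a weak result that sets the only reference point for the whole set.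

Compound 3 `O=C1O/C(=C\Cn2cnc3cncc(Br)c32)C(OCc2ccccc2)=C1OCc1ccccc1` is not yet measured. Relative to compound 1 the change is a group of 10 heavy atoms (6 carbon, 3 nitrogen, 1 bromine; one five-membered aromatic ring with 2 hetero atoms, one six-membered aromatic ring with 1 hetero atom) in place of a group of 12 heavy atoms (6 carbon, 3 nitrogen, 2 fluorine, 1 chlorine; one five-membered aromatic ring with 2 hetero atoms, one six-membered aromatic ring with 1 hetero atom), on a saturated chain carbon bound to a double-bonded chain carbon. Among the compounds with values here, since compound 1 has no number in this assay, no step from compound 1 to compound 3 can be sized or given a direction; the only anchor is the weak figure of compound 2, and nothing in the data shows that the smaller single-heterocycle arrangement of compound 3 should read very differently from it.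

On that basis compound 3 is expected to land near 25000 nM in this assay, with a plausible span from 6000 nM to 100000 nM, and a real chance that only a limit is reported.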

Compound 3, half-maximal inhibitory concentration: 5700 nM
Compound 3: middle estimate off by 4.4-fold (0.64 log units), on the high side; the measured number lies below the stated range.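

No step can be read from compound 1 to compound 3: in this assay compound 1 gives "not determined" (no result reported) and compound 3 gives 5700 nM with nothing to set it against. The compounds shown leave open how exchanging the two groups alone bears on antiproliferative activity. No evidence bearing on this result is available.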